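Swapping the Heteroaryl on Sulfur: Tetrazole to Methyltriazole

The compounds below may be only part of what the source reports. "The series", "measured", "known", "first", "only" and "open" are said of these compounds alone.

Compound 3 `O=C(CSc1nnnn1-c1ccccc1)N/N=c1/scc(-c2ccc(F)cc2)n1-c1ccccc1` is tested in an ADME assay on NIH3T3 cells (Mus musculus) for cytotoxicity, read by MTT assay, with a stated time of 24 h (a lower number here means a stronger inhibitor, a higher number a weaker inhibitor), and gives 207 ug/mL. Among the two plain numbers here it is the higher one, though its neighbour compound 2 `COc1ccc(-c2cs/c(=N/NC(=O)CSc3nncn3C)n2-c2ccccc2)cc1`, which gives 167 ug/mL, sits within the scatter of it. Compound 1 `O=C(CSc1ncccn1)N/N=c1/scc(-c2ccc(F)cc2)n1-c1ccccc1` gives only a limit of the assay, > 500 ug/mL. Going by the values given here, the one measured step, an at least 2.4-fold lower number from compound 1 to compound 3 (0.38 log units; beyond the scatter), shows that changing the heteroaryl group on the sulfur can move the number. Compound 4 `Cn1cnnc1SCC(=O)N/N=c1/scc(-c2ccc(F)cc2)n1-c1ccccc1` carries the change (4-methyl-4H-1,2,4-triazol-3-yl in place of 1-phenyl-1H-tetrazol-5-yl on a sulfur). Compound 2 bears this same 4-methyl-4H-1,2,4-triazol-3-yl group and gives a number close to compound 3, so the step of a 1.2-fold lower number from compound 3 to compound 4 (0.06 log units; within the scatter) is expected to stay within the scatter. Compound 4 is therefore estimated at 180 ug/mL, with a range of 90 ug/mL to 360 ug/mL.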

Compound 4, half-maximal inhibitory concentration: 65 ug/mL
The estimate for compound 4 lay 2.8-fold (0.44 log units) above the measured number; measured number outside the range, below it.
By their numbers in this assay, from the lowest: compound 4; then compounds 2 and 3 (each within the scatter of the next). At a limit, above all of these: compound 1.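

On this sulfur, 4-methyl-4H-1,2,4-triazol-3-yl in place of 1-phenyl-1H-tetrazol-5-yl gives a 3.2-fold lower number from compound 3 to compound 4 (0.50 log units; beyond the scatter) in this assay with the rest of the molecule unchanged. The group on the sulfur does not set the number alone: fluoro in place of methoxy on an aromatic carbon gives a 2.6-fold lower number from compound 2 to compound 4 (0.41 log units; beyond the scatter) while this triazole stays in place. The step of an at least 7.6-fold lower number from compound 1 to compound 4 (0.88 log units; beyond the scatter) gives only a bound on its size, for compound 1 stands at a limit of the assay: the limit of > 500 ug/mL in this assay, at which 1 of the 4 values shown sits.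

Going by these compounds, what a longer chain carrying an amine on this sulfur would do remains open.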